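Swapping an amine on two related cores

The compounds below may be only part of what the source reports. "The series", "measured", "known", "first", "only" and "open" are said of these compounds alone.

The compounds here share a small fused two-ring core carrying an amine, and they were tested in a functional assay on EL4 cells (Mus musculus) for inhibition, tested at 100 uM; a higher number here means more inhibition at the concentration tested (going by the name of the read-out), a lower number less inhibition. Compound 2 `CN(C)c1[nH]ccc2ncnc1-2` gives 25% in this assay. Compound 1 `OCCNc1[nH]ccc2ncnc1-2` differs from it in one place, ((2-hydroxyethyl)amino in place of dimethylamino on an aromatic carbon), and the step of a number at least 20 percentage points lower from compound 2 to compound 1 (beyond the scatter). The value for compound 1 is a limit of this assay, not a number, namely < 5%; in this set (the limit of < 5% in this assay, at which 1 of the 3 values shown sits). Compound 3 `CN(C)c1nccc2c1ncn2C1O[C@H](CO)[C@@H](O)[C@H]1O` has a different core, and the difference between the two cores is not broken down here. In this assay compound 3 gives 10%, which is lower than the number for compound 2 and beyond the scatter.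

Compound 4 `OCCNc1nccc2c1ncn2C1O[C@H](CO)[C@@H](O)[C@H]1O` has not been measured. It stands to compound 3 as compound 1 stands to compound 2: (2-hydroxyethyl)amino in place of dimethylamino on an aromatic carbon. The two places are described in the same words, so this is the same kind of change on a different core. Because compound 1 sits at the limit (the limit of < 5% in this assay, at which 1 of the 3 values shown sits), the earlier step is known only as a lower bound of its size. That earlier drop from compound 2 to compound 1 was at least modest, and compound 3 already gives 10% in this assay, which leaves little room for a further drop of the same size. On that basis the expected step is a number 7 percentage points lower from compound 3 to compound 4 (within the scatter). Compound 4 is therefore estimated at 3%, with a likely range from 0% to 10%, and it may well be reported only as a limit.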

Compound 4, a percentage reported as inhibition, at one concentration (the size of the read-out at that concentration, not a potency): 6%
Compound 4: middle estimate off by 3 percentage points, on the low side; the range from low to high includes it.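

In this assay, the same swap of dimethylamino for (2-hydroxyethyl)amino on the second core gives a number 4 percentage points lower from compound 3 to compound 4 (within the scatter), so on this core the change has no effect that can be told from the scatter. The change therefore does not carry over from one core to the other with the same size: the same change on two cores in this assay, a number at least 20 percentage points lower (beyond the scatter) from compound 2 to compound 1 and a number 4 percentage points lower (within the scatter) from compound 3 to compound 4, at least 16 percentage points apart, beyond the scatter of two such steps. Compound 1 is reported only as a limit, and with a single pair on each core, the result does not show why the two steps differ, how large the gap really is, or what the change would do on any further core: the limit of < 5% in this assay, at which 1 of the 4 values shown sits.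

The compounds shown leave open whether the difference between the two cores would also appear with other amines in this place, such as a morpholine ring or a simple methylamino group. They also leave open what a longer chain, such as (3-hydroxypropyl)amino, would do on each core, and every number here comes from a single test concentration, so none of them says how potent a compound is.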